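Configuration change in a tetravalent iminosugar cluster

This account rests on a few compounds, and the source may have more. Where it says the series, first, only, none or still open, it means among the compounds named here.

Measured so far:
compound 1 `O[C@@H]1[C@H](O)CN[C@H]1Cn1cc(CCCn2cc(COCC(COCc3cn(CCCc4cn(C[C@@H]5NC[C@@H](O)[C@H]5O)nn4)nn3)(COCc3cn(CCCc4cn(C[C@@H]5NC[C@@H](O)[C@H]5O)nn4)nn3)COCc3cn(CCCc4cn(C[C@@H]5NC[C@@H](O)[C@H]5O)nn4)nn3)nn2)nn1` gives 897000 nM
compound 2 `NC(COCc1cn(CCCc2cn(C[C@H]3NC[C@@H](O)[C@H]3O)nn2)nn1)(COCc1cn(CCCc2cn(C[C@H]3NC[C@@H](O)[C@H]3O)nn2)nn1)COCc1cn(CCCc2cn(C[C@H]3NC[C@@H](O)[C@H]3O)nn2)nn1` gives 309000 nM

In an assay on isolated protein for inhibition of alpha-galactosidase A (Homo sapiens), read by fluorescence and spectrophotometry, with stated times of 45 min and 30 min (on this read-out higher numbers stand for weaker inhibition and lower numbers for stronger inhibition), compound 1 stands at the highest number of the two measured compounds, and compound 2 sits at a lower number, the gap lying beyond the scatter. Compound 3 `O[C@@H]1[C@H](O)CN[C@@H]1Cn1cc(CCCn2cc(COCC(COCc3cn(CCCc4cn(C[C@H]5NC[C@@H](O)[C@H]5O)nn4)nn3)(COCc3cn(CCCc4cn(C[C@H]5NC[C@@H](O)[C@H]5O)nn4)nn3)COCc3cn(CCCc4cn(C[C@H]5NC[C@@H](O)[C@H]5O)nn4)nn3)nn2)nn1` keeps the core of compound 1 and differs only as follows: the two compounds have the same atoms and bonds and differ only in configuration as drawn: 4 of 12 stereo elements differ; a stereocentre at a saturated ring carbon is drawn S in compound 1 and R in compound 3; a stereocentre at a saturated ring carbon is drawn S in compound 1 and R in compound 3; a stereocentre at a saturated ring carbon is drawn S in compound 1 and R in compound 3; a stereocentre at a saturated ring carbon is drawn S in compound 1 and R in compound 3. The configuration drawn at those ring carbons in compound 3 is the one present in the iminosugar units of compound 2, which gives 309000 nM. For the measured compounds named here, no pair of measured compounds differing in one place is available, so the size of the step rests on this comparison alone. A shift to a lower number is expected from compound 1 to compound 3, of size a 3.0-fold lower number from compound 1 to compound 3 (0.48 log units; beyond the scatter), with wide uncertainty either way. Compound 3 is estimated at 300000 nM, within 50000 nM to 1500000 nM.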

Compound 3, half-maximal inhibitory concentration: 142000 nM
The estimate for compound 3 lay 2.1-fold (0.32 log units) above the measured number; measured number inside the range.
By their numbers in this assay, from the lowest: compound 3; then compound 2; then compound 1.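

Inverting four stereo elements, each a saturated ring carbon drawn S in compound 1 and R in compound 3, gives in this assay a 6.3-fold lower number from compound 1 to compound 3 (0.80 log units; beyond the scatter). For the compounds shown here, the earlier compounds offered no pair differing in one place, so this is the first measured step, and it places the configuration at these carbons among the things this read-out responds to. The shift can be assigned to configuration alone, with no change of constitution involved: the fact that compounds 1 and 3 differ only in the configuration as drawn

As far as these compounds go, the four carbons change together in this pair, so it remains open whether they contribute equally or whether fewer of them carry the step. Also open, from the compounds shown here alone, is whether the same direction and size of step would hold with a longer chain in the arms or with a carboxylic acid on the units.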